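From hydroxy to phenyl in a growth inhibition series

A few compounds are considered here, and "the series" means these few. Any claim that something is new, unique, unknown or untested is made for them only; others in the source may bear on it.

Compound 1 `C=CCc1cc(O)c(O)c(CN2CCC(C)CC2)c1`: 91.5%
Compound 2 `C=CCc1cc(O)c(O)c(CN2CCC(CCO)CC2)c1`: 54.4%
Compound 3 `C=CCc1cc(O)c(O)c(CN2CCC(CO)CC2)c1`: 34.1%

In a functional assay on MIA PaCa-2 cells (Homo sapiens) for inhibition, read by MTT assay, with a stated time of 72 h, tested at 30 uM (a lower number here means less inhibition of growth, a higher number more inhibition of growth at the concentration tested), compound 3 gives 34.1%, the lowest of the three numbers, and both other compounds lie beyond the scatter from it. The next compound to be measured is compound 4 `C=CCc1cc(O)c(O)c(CN2CCC(Cc3ccccc3)CC2)c1`, which keeps the shared core and changes one group: phenyl in place of hydroxy on a saturated chain carbon bound to a saturated ring carbon.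

Among the compounds with values here, no measured step involves phenyl, so the evidence is indirect. Two large steps bear on the change: a number 57.4 percentage points lower from compound 1 to compound 3 (beyond the scatter) and a number 37.1 percentage points lower from compound 1 to compound 2 (beyond the scatter). Within the data shown here, each leads from the one compound without hydroxy to a compound that carries it. A modest step, a number 20.3 percentage points lower from compound 2 to compound 3 (beyond the scatter), separates the two hydroxy compounds. Compound 4 carries no hydroxy either, and compound 1, likewise without it, reaches 91.5%. Among the measured compounds shown here, on that ground a large rise is expected, though the series offers only three compounds and nothing on a group as big as phenyl. The expected change is a number 47.9 percentage points higher from compound 3 to compound 4 (beyond the scatter). For compound 4 the estimated value is 82%, with an expected range from 60% to 98%.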

Compound 4, percent growth inhibition at one concentration: 88.9%
Estimate against measurement, compound 4: 6.9 percentage points below; the range from low to high includes it.
By their numbers in this assay, from the lowest: compound 3; then compound 2; then compounds 4 and 1 (each within the scatter of the next).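

In this assay, within the data shown here, phenyl in place of hydroxy at this saturated chain carbon gives a number 54.8 percentage points higher from compound 3 to compound 4 (beyond the scatter), and phenyl in place of hydroxymethyl gives a number 34.5 percentage points higher from compound 2 to compound 4 (beyond the scatter), so the position tolerates a group of six heavy atoms with an aromatic ring, something the earlier compounds could not show. Phenyl in place of hydrogen gives a number 2.6 percentage points lower from compound 1 to compound 4 (within the scatter), so a methyl and a benzyl on the shared core cannot be told apart here, and the size of the group alone does not separate the compounds shown. Within these four compounds, the two that carry a hydroxy group are the two with the lower numbers, and neither of the other two goes against this pattern.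

From the compounds shown here alone, whether an amine, a carboxylic acid or a longer chain without hydroxy at this place would stay level with compound 1 and compound 4 remains open, as does whether a substituted phenyl would do so. Nothing given here accounts for why the hydroxy compounds differ from the other two.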